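The source may report more compounds than this note shows. Statements on the series, on what has been measured and on what is new or still open speak of the compounds shown alone.

Measured in an ADME assay on the whole organism (Mus musculus, strain Swiss Webster) for pharmacokinetics, read by LC-MS, at a dose of 50 mg/kg by the oral route; a lower number here means less compound in the circulation, a higher number more compound in the circulation at the dose given:
Compound 1 `O=C(Nc1ccc(F)c(-c2nc3ncc(-c4ccc(F)cc4F)cc3[nH]2)c1)N1CCCC1`: 15600 ng.h/mL
Compound 2 `O=C(Nc1ccc(F)c(-c2nc3ncc(-c4cccc(F)c4)cc3[nH]2)c1)N1CCCC1`: 15000 ng.h/mL

Compound 2, at 15000 ng.h/mL, lies within the scatter of compound 1, so the two cannot be told apart in this assay. Compound 3 `O=C(Nc1ccc(F)c(-c2nc3ncc(-c4cc(F)cc(F)c4)cc3[nH]2)c1)N1CCCC1` differs from compound 2 by one change, fluoro in place of hydrogen on an aromatic carbon. Within the data shown here, the only measured step that bears on it is a 1.0-fold lower number from compound 1 to compound 2 (0.02 log units; within the scatter), which also changes the fluoro groups on that aryl group. No shift beyond the scatter is therefore expected, and the estimated change is no change at the digits printed from compound 2 to compound 3 (within the scatter). The estimate for compound 3 is 15000 ng.h/mL, with an expected range of 7000 ng.h/mL to 32000 ng.h/mL.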

Compound 3, area under the concentration-time curve: 9400 ng.h/mL
For compound 3 the middle estimate is 1.6-fold (0.20 log units) above the measured one; the range from low to high includes it.
By their numbers in this assay, from the lowest: compounds 3, 2 and 1 (each within the scatter of the next).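

In this assay, among these compounds, fluoro in place of hydrogen on the 3-fluorophenyl group, meta to a fluoro group, gives a 1.6-fold lower number from compound 2 to compound 3 (0.20 log units; within the scatter) and thus no step that can be told from scatter. The same holds for 3,5-difluorophenyl in place of 2,4-difluorophenyl, which gives a 1.7-fold lower number from compound 1 to compound 3 (0.22 log units; within the scatter) and so shows that neither this second fluoro nor this arrangement of the two separates the compounds. Still open, from the compounds shown here alone, is whether a chloro, a methoxy or an amine on this aryl group would move the number beyond the scatter. Nothing available explains these numbers.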